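The source may report more compounds than this note shows. Statements on the series, on what has been measured and on what is new or still open speak of the compounds shown alone.

Compound 2 `COc1cccc(/C=C/C(=O)c2ccncc2)c1` is one of three related chalcone-type compounds assessed in an assay on cell membranes for inhibition of cytochrome P450 1A1 (Homo sapiens), read by fluorescence, using microsomes, with a stated time of 10 min; a lower number here means a stronger inhibitor, a higher number a weaker inhibitor. Compound 1 `CCOc1cc(/C=C/C(=O)c2ccncc2)cc(OC)c1OC` gives 63 nM in this assay, and compound 3 `CCOc1cc(/C=C/C(=O)c2ccncc2)cc(OC)c1OCC` gives 65 nM. Compound 2 gives 590 nM, the highest of the three numbers; the two ring-substituted analogues both lie well below it, the closest being compound 3 and the farthest compound 1.

Going by the values given here, the one single-point step among the measured compounds, a 1.0-fold higher number from compound 1 to compound 3 (0.01 log units; within the scatter), involves a change on a side chain rather than on the ring itself and so offers little guidance here.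

Compound 4 `COc1ccc(/C=C/C(=O)c2ccncc2)cc1OC` differs from compound 2 as follows: methoxy in place of hydrogen on an aromatic carbon. The change places a second methoxy on the ring, ortho to the existing methoxy group and para to a large group, carrying the structure partway toward the more heavily substituted compounds 1 and 3. Among the compounds with values here, no measured step isolates this exact change, but the values of compound 2 and compound 3 show that adding ring alkoxy groups has gone with clearly lower numbers.

On that basis a downward step a 3.0-fold lower number from compound 2 to compound 4 (0.47 log units; beyond the scatter) is expected in this assay, though smaller than the full gap to compound 3. Compound 4 is therefore estimated at 200 nM, with a range of 80 nM to 500 nM.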

Compound 4, half-maximal inhibitory concentration: 380 nM
The estimate for compound 4 lay 1.9-fold (0.28 log units) below the measured number; the measured number falls inside the stated range.
By their numbers in this assay, from the lowest: compounds 1 and 3 (each within the scatter of the next); then compounds 4 and 2 (each within the scatter of the next).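

In this assay, methoxy in place of hydrogen on an aromatic carbon, ortho to a methoxy group and para to a large group, gives a 1.6-fold lower number from compound 2 to compound 4 (0.19 log units; within the scatter) and so does not by itself separate these two compounds beyond the usual scatter. Going by these compounds alone, the ethoxy group of compound 1 marks a clearer difference: hydrogen in place of ethoxy on an aromatic carbon gives a 6.0-fold higher number from compound 1 to compound 4 (0.78 log units; beyond the scatter) and is the first single-place step in this set to lie beyond the scatter, showing that a change on the ring can matter even though the added methoxy did not. No measured information on why these two ring changes differ accompanies these results.

The compounds shown leave open whether the ethoxy step depends on the other ring alkoxy groups or would look the same on a ring carrying fewer of them. They also leave open how a longer chain such as propoxy, or an amine or a fluorine atom, would read on the same aromatic carbons.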